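The source may report more compounds than this note shows. Statements on the series, on what has been measured and on what is new or still open speak of the compounds shown alone.

In a functional assay on MDA-MB-231 cells (Homo sapiens) for antiproliferative activity, read by MTT assay, with a stated time of 72 h (a lower number here means a stronger inhibitor, a higher number a weaker inhibitor), compound 1 `O=C(CCc1cccc2c1B(O)OC2)Nc1cccc(Br)c1` gives 720 nM, compound 2 `CC(C)c1cccc(NC(=O)CCc2cccc3c2B(O)OC3)c1` gives 1600 nM, and compound 3 `COc1ccc(-c2cccc(NC(=O)CCc3cccc4c3B(O)OC4)c2)cc1` gives 88 nM, the lowest of the three numbers. Compound 4 `CSc1ccc(-c2cccc(NC(=O)CCc3cccc4c3B(O)OC4)c2)cc1` differs from compound 3 by methylsulfanyl in place of methoxy on an aromatic carbon. Among the measured compounds shown here, no measured step tests this exchange directly. The 4-methoxyphenyl group brought an 8.2-fold lower number from compound 1 to compound 3 (0.91 log units; beyond the scatter) and an 18-fold lower number from compound 2 to compound 3 (1.26 log units; beyond the scatter), while replacing bromo with isopropyl brought a 2.2-fold higher number from compound 1 to compound 2 (0.35 log units; beyond the scatter). All three exchanged much more different groups than this one does, so no clear shift in either direction is expected in this assay. The expected step, a 1.1-fold higher number from compound 3 to compound 4 (0.06 log units; within the scatter), stays within the scatter. Compound 4 is estimated at 100 nM, with an expected range of 40 nM to 250 nM.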

Compound 4, half-maximal inhibitory concentration: 140 nM
Compound 4: the middle estimate sits 1.4-fold (0.15 log units) below what was measured; the range from low to high includes it.
By their numbers in this assay, from the lowest: compounds 3 and 4 (each within the scatter of the next); then compound 1; then compound 2.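

In this assay, the position para to a large group takes methylsulfanyl in place of methoxy with no change beyond the scatter (a 1.6-fold higher number from compound 3 to compound 4 (0.20 log units; within the scatter)). The advantage over isopropyl (an 11-fold lower number from compound 2 to compound 4 (1.06 log units; beyond the scatter)) and bromo (a 5.1-fold lower number from compound 1 to compound 4 (0.71 log units; beyond the scatter)) therefore does not depend on the methoxy oxygen, as 4-(methylsulfanyl)phenyl retains it. Nothing given here explains these steps.

The compounds shown leave open how an amine, a carboxylic acid or a longer chain such as ethoxy would fare at this position. They also leave open whether a plain phenyl, with only hydrogen there, would hold the same level.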